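This account rests on a few compounds, and the source may have more. Where it says the series, first, only, none or still open, it means among the compounds named here.

The measured compounds:
compound 1, `O=C(COc1cccc2ccccc12)N/N=C/C=C/c1ccccc1`, 100 ug/mL
compound 2, `O=C(COc1cccc2ccccc12)N/N=C/c1ccc(Br)cc1`, > 100 ug/mL

In an ADME assay on HEL cells (Homo sapiens) for cytotoxicity (a lower number here means that less compound is tolerated, a higher number that more compound is tolerated), compound 1 gives 100 ug/mL. Compound 2 reaches only a limit of the assay, > 100 ug/mL. Among the measured compounds shown here, the single measured step, a number no lower from compound 1 to compound 2 (the limit leaves the size open), therefore cannot be sized, because the limit of > 100 ug/mL in this assay, at which 1 of the 2 values shown sits, is all that is recorded for compound 2. Compound 2 thus stands at the limit, without a number of its own.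

Compound 3 is `CSc1ccc(/C=N/NC(=O)COc2cccc3ccccc23)cc1`. The change from compound 2 to compound 3 is methylsulfanyl in place of bromo on an aromatic carbon. For the measured compounds named here, no measured step touches this position: the one step that exists exchanges the 2-phenylethenyl for the 4-bromophenyl on the carbon with the double bond to nitrogen, and it leaves the size open. Nothing in the two values speaks for a move in either direction beyond the scatter when bromo gives way to methylsulfanyl, para to a large group.

Compound 3 is therefore expected at 100 ug/mL, in a range from 50 ug/mL to 200 ug/mL. The expected step is a number no higher from compound 2 to compound 3 (the limit leaves the size open), no larger than the scatter.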

Compound 3, minimum cytotoxic concentration: >= 100 ug/mL
Compound 3: a limit, no number; the forecaster's own chance of this, stated with the estimate: 60%; the middle value sits exactly at the limit.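

In this assay compound 3 gives >= 100 ug/mL, which is a limit and not a number, so methylsulfanyl on this aromatic carbon, like the bromo of compound 2, yields no exact value. The exchange of 2-phenylethenyl for 4-(methylsulfanyl)phenyl gives a number no lower from compound 1 to compound 3 (the limit leaves the size open), the same direction as the 4-bromophenyl exchange, which gave a number no lower from compound 1 to compound 2 (the limit leaves the size open); two different groups in this position thus share that direction. The size of these steps and the step between bromo and methylsulfanyl cannot be read, because only limits are recorded for compound 2 and compound 3, as with compound 3: the limit of >= 100 ug/mL in this assay, at which 1 of the 3 values shown sits.

The compounds shown leave open how far compound 2 and compound 3 actually lie from each other and from compound 1. They also leave open whether an amine or a carboxylic acid on the same aromatic carbon would give a number rather than a limit, and so allow a step at this position to be sized.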